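Trifluoromethyl for methyl on the shared core of compound 3

The compounds below may be only part of what the source reports. "The series", "measured", "known", "first", "only" and "open" are said of these compounds alone.

Of the compounds shown here, three have been measured in a functional assay on the whole organism (aorta) with Rattus norvegicus as the target; on this read-out lower numbers stand for smaller maximal responses and higher numbers for larger maximal responses. Compound 1 `CNC(=O)C1=CC(C(F)(F)F)(C(F)(F)F)Oc2ccc([N+](=O)[O-])cc21` gives 57.9%, compound 2 `N#CCC/N=C(/S)C1=CC(C(F)(F)F)(C(F)(F)F)Oc2ccc([N+](=O)[O-])cc21` gives 74.8%, and compound 3 `CC1(C(F)(F)F)C=C(C(=O)NCCC#N)c2cc([N+](=O)[O-])ccc2O1` gives 70.6%. Compound 3 thus stands second highest of the three: its value lies within the scatter of compound 2, and beyond the scatter above compound 1. Compound 4 `N#CCCNC(=O)C1=CC(C(F)(F)F)(C(F)(F)F)Oc2ccc([N+](=O)[O-])cc21` differs from compound 3 by trifluoromethyl in place of methyl on a saturated ring carbon. Going by the values given here, the only measured step, a number 16.9 percentage points higher from compound 1 to compound 2 (beyond the scatter), concerns a different part of the molecule and does not bear on this exchange, so no firm basis exists for predicting a direction. The expected step of a number 0.6 percentage points lower from compound 3 to compound 4 (within the scatter) therefore stays within the scatter, and compound 4 is estimated at 70%, between 55% and 85%.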

Compound 4, intrinsic activity: the largest response reached, in percent of the reference agonist's: 64.1%
For compound 4 the middle estimate is 5.9 percentage points above the measured one; the range from low to high includes it.
By their numbers in this assay, from the lowest: compounds 1, 4, 3 and 2 (each within the scatter of the next, the first and the last beyond it).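

In this assay, trifluoromethyl in place of methyl on the saturated ring carbon next to the ring oxygen gives a number 6.5 percentage points lower from compound 3 to compound 4 (within the scatter), so this exchange cannot be told apart from repeat-measurement noise. Cyanomethyl in place of hydrogen on the chain carbon bound to the amide-type nitrogen gives a number 6.2 percentage points higher from compound 1 to compound 4 (within the scatter), also unresolved, whereas the oxygen-bearing group in place of the sulfur-bearing one gives a number 10.7 percentage points lower from compound 2 to compound 4 (beyond the scatter), the only new step beyond the scatter. Nothing measured here explains these steps. On these data alone, whether ethyl or a chlorine atom on this ring carbon would shift the maximal response beyond the scatter remains open.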